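Swapping a lactam for an acetylated pyrrolidine

A few compounds are considered here, and "the series" means these few. Any claim that something is new, unique, unknown or untested is made for them only; others in the source may bear on it.

Of the compounds shown here, three sharing one core have been tested in an assay on isolated protein for binding affinity to secreted frizzled-related protein 1 (Homo sapiens), read by fluorescence; a lower number here means a stronger inhibitor, a higher number a weaker inhibitor. Compound 1 `CN(C)CC(=O)N1CCC(NS(=O)(=O)c2cc(S(=O)(=O)c3ccccc3)ccc2C(F)(F)F)CC1` gives 300 nM. Compound 2 `O=C(Cn1ccnc1)N1CCC(NS(=O)(=O)c2cc(S(=O)(=O)c3ccccc3)ccc2C(F)(F)F)CC1` gives 30 nM. Compound 3 `O=C1CC[C@@H](C(=O)N2CCC(NS(=O)(=O)c3cc(S(=O)(=O)c4ccccc4)ccc3C(F)(F)F)CC2)N1` gives 90 nM, which places it second of the three, between the other two. The steps of a 10-fold lower number from compound 1 to compound 2 (1.00 log units; beyond the scatter), a 3.3-fold lower number from compound 1 to compound 3 (0.52 log units; beyond the scatter) and a 3.0-fold higher number from compound 2 to compound 3 (0.48 log units; beyond the scatter) show that exchanging the group on the carbonyl carbon shifts the numbers by modest amounts. Compound 4 `CC(=O)N1CCC[C@H]1C(=O)N1CCC(NS(=O)(=O)c2cc(S(=O)(=O)c3ccccc3)ccc2C(F)(F)F)CC1` carries the change (1-acetylpyrrolidin-2-yl in place of 5-oxopyrrolidin-2-yl on a carbonyl carbon). Among the compounds with values here, none of the measured steps tests this exact exchange, so the direction is uncertain; a modest step is expected, a 1.3-fold higher number from compound 3 to compound 4 (0.12 log units; within the scatter), in line with the sizes of a 3.3-fold lower number from compound 1 to compound 3 (0.52 log units; beyond the scatter) and a 3.0-fold higher number from compound 2 to compound 3 (0.48 log units; beyond the scatter). For compound 4 in this assay the expected value is 120 nM, within a range from 40 nM to 400 nM.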

Compound 4, half-maximal inhibitory concentration: 160 nM
Compound 4: the middle estimate sits 1.3-fold (0.12 log units) below what was measured; the measured number falls inside the stated range.
By their numbers in this assay, from the lowest: compound 2; then compounds 3, 4 and 1 (each within the scatter of the next, the first and the last beyond it).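

On this carbonyl carbon, 1-acetylpyrrolidin-2-yl has no hydrogen-bond donor, unlike 5-oxopyrrolidin-2-yl, yet the exchange stays within the scatter (a 1.8-fold higher number from compound 3 to compound 4 (0.25 log units; within the scatter)). Compound 4 is clearly weaker than the (1H-imidazol-1-yl)methyl compound (a 5.3-fold higher number from compound 2 to compound 4 (0.73 log units; beyond the scatter)), but is not separated from the (dimethylamino)methyl compound (a 1.9-fold lower number from compound 1 to compound 4 (0.27 log units; within the scatter)). No measurement available here explains these numbers. Still open, going by these compounds, is how a carboxylic acid on this carbonyl carbon, or a longer chain ending in 1H-imidazol-1-yl, would compare with compound 2.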